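Cytotoxicity notes on a chain-extended analogue

The source may report more compounds than this note shows. Statements on the series, on what has been measured and on what is new or still open speak of the compounds shown alone.

Measured so far:
compound 1 `CCC1(c2cccc(Cl)c2)ON=C(c2ccccc2Cl)O1` — > 100000 nM
compound 2 `CC1(c2cccc(Br)c2)ON=C(c2ccccc2Cl)O1` — > 100000 nM

In an ADME assay on HEK293 cells (Homo sapiens) for cytotoxicity, read by MTT assay, with a stated time of 44 h (a higher number here means a weaker inhibitor, a lower number a stronger inhibitor), compound 1 gives only a limit, > 100000 nM. In this assay compound 2 likewise gives only a limit, > 100000 nM. Compound 2 thus stands where every value shown stands, at the limit of > 100000 nM in this assay, at which 2 of the 2 values shown sit; no number is available for either compound.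

Compound 3 `CCC1(c2cccc(Br)c2)ON=C(c2ccccc2Cl)O1` differs from compound 2 by methyl in place of hydrogen on a saturated chain carbon bound to a saturated ring carbon. The measured pair does not isolate this change, so no step beyond the scatter is expected in this assay. Compound 3 is expected to give about 150000 nM (range 60000 nM to 400000 nM), most likely again reported as a limit. The expected step is a step that the limit leaves unreadable from compound 2 to compound 3.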

Compound 3, half-maximal inhibitory concentration: > 100000 nM
Compound 3: a limit, no number; the forecaster's own chance of this, stated with the estimate: 85%; the middle value is on the limit's open side.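

No step can be read from compound 1 or compound 2 to compound 3, as all three give only a limit: the limit of > 100000 nM in this assay, at which 3 of the 3 values shown sit.

From the compounds shown here alone, whether methyl in place of hydrogen or bromo in place of chloro changes the cytotoxicity of this series remains open.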